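Methoxy for methyl at the carbonyl of compound 2

A few compounds are considered here, and "the series" means these few. Any claim that something is new, unique, unknown or untested is made for them only; others in the source may bear on it.

In a functional assay on COLO 205 cells (Homo sapiens) for cytotoxicity, read by MTT assay, with a stated time of 24 h (on this read-out lower numbers stand for stronger inhibition and higher numbers for weaker inhibition), compound 2 `CC(=O)C[Se]C(=O)c1ccc(Cl)cc1` gives 5480 nM as the higher of the two actual numbers. Compound 1 `CC(C)(C)C(=O)C[Se]C(=O)c1ccc(Cl)cc1` sits nearest at 1630 nM on the lower side. Compound 3 `NC(=O)C[Se]C(=O)c1ccccc1` gives > 100000 nM which is a limit of the assay and not a number. Compound 4 `COC(=O)C[Se]C(=O)c1ccc(Cl)cc1` differs from compound 2 by methoxy in place of methyl on a carbonyl carbon and awaits measurement. Within the data shown here, one measured step bears on this carbonyl carbon. Among the measured compounds shown here, with a 3.4-fold higher number from compound 1 to compound 2 (0.53 log units; beyond the scatter) as the only guide, a similarly modest move toward a higher number is expected as a 1.6-fold higher number from compound 2 to compound 4 (0.22 log units; within the scatter) on this thin evidence. The estimated value for compound 4 is 9000 nM within an expected range of 2500 nM to 32000 nM for this measurement.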

Compound 4, half-maximal inhibitory concentration: > 100000 nM
Compound 4: a limit, no number; the forecaster's own chance of this, stated with the estimate: 10%; middle value at least 11-fold (1.04 log units) from the limit.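

In this assay, putting methoxy on this carbonyl carbon costs far more than exchanging one carbon group for another: the change gives an at least 18-fold higher number from compound 2 to compound 4 (1.26 log units; beyond the scatter) and an at least 61-fold higher number from compound 1 to compound 4 (1.78 log units; beyond the scatter), both large, whereas the swap of tert-butyl for methyl gives only a 3.4-fold higher number from compound 1 to compound 2 (0.53 log units; beyond the scatter). Compound 4 gives a limit and not a number, so neither step has a known full size: the limit of > 100000 nM in this assay, at which 2 of the 4 values shown sit.

Still open, on these data alone, is how an ethyl group or a longer chain on this carbonyl carbon would behave. A carboxylic acid at the same place is equally unresolved.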